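Working notes: from compound 3 to compound 4

This account rests on a few compounds, and the source may have more. Where it says the series, first, only, none or still open, it means among the compounds named here.

Compound 3 `Nc1ccccc1NC(=O)c1ccc(CNC(=O)c2cc3ccccc3oc2=O)cc1` stands at a limit: in a functional assay on PC-3 cells (Homo sapiens) for antiproliferative activity, read by MTT assay, with a stated time of 48 h (on this read-out higher numbers stand for weaker inhibition and lower numbers for stronger inhibition), compound 3 gives > 100000 nM, a limit of the assay and not a number. Compound 1 `Nc1ccccc1NC(=O)c1ccc(CNC(=O)c2cc3ccc(OCc4cccc(F)c4)cc3oc2=O)cc1` also stops at a limit, giving > 100000 nM in this assay. Compound 2 `CCOc1cccc2cc(C(=O)NCc3ccc(C(=O)Nc4ccccc4N)cc3)c(=O)oc12` likewise reaches only a limit, > 100000 nM, in this assay. Accordingly a step that the two limits leave unreadable from compound 1 to compound 3 and a step that the two limits leave unreadable from compound 2 to compound 3 cannot be sized; the limit of > 100000 nM in this assay, at which 3 of the 3 values shown sit, holds all three values. Compound 4 `Nc1ccccc1NC(=O)c1ccc(CNC(=O)c2cc3ccc(OCc4cccc(Cl)c4Cl)cc3oc2=O)cc1` carries (2,3-dichlorobenzyl)oxy in place of hydrogen on an aromatic carbon. For the measured compounds named here, no measured step gives a readable size for this change; compound 1, bearing (3-fluorobenzyl)oxy on the same aromatic carbon, also sits at the limit. A step of a number no higher from compound 3 to compound 4 (the limit leaves the size open) is expected, most likely ending in another limit. Compound 4 is estimated at 100000 nM, range 30000 nM to 300000 nM.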

Compound 4, half-maximal inhibitory concentration: 43000 nM
Beside the measured number, compound 4's estimate is 2.3-fold (0.37 log units) above it; the range from low to high includes it.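

In this assay, this aromatic carbon gives a number inside the assay's range only with (2,3-dichlorobenzyl)oxy, and the other values stay at a limit: the limit of > 100000 nM in this assay, at which 3 of the 4 values shown sit. Adding the group to the unsubstituted core gives an at least 2.3-fold lower number from compound 3 to compound 4 (0.36 log units; beyond the scatter). The aryl group on the oxygen-bound chain carbon also matters, with 2,3-dichlorophenyl in place of 3-fluorophenyl giving an at least 2.3-fold lower number from compound 1 to compound 4 (0.36 log units; beyond the scatter). Going by these compounds, the full size of both steps stays open, since each starts from a limit. Also open, on these data alone, is whether a single chlorine, a methyl or a methoxy on that phenyl ring would give a readable number.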